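The source may hold more compounds than are shown below. What is called first, only, known or untested is meant among the compounds shown, and "the series" means these compounds.

Going by the values given here, in a functional assay on HT-29 cells (Homo sapiens) for inhibition, read by MTT assay, with a stated time of 72 h (a higher number here means a weaker inhibitor, a lower number a stronger inhibitor), compound 2 `CCN(CC)CCCn1c(=O)c(=Cc2ccc(F)c(F)c2)s/c1=C1\C(=O)Nc2ccc(F)cc21` gives 640 nM, the lowest number of the two measured so far. Among the compounds with values here, its nearest neighbour, compound 1 `CN(C)CCn1c(=O)c(=Cc2ccc(F)cc2F)s/c1=C1\C(=O)Nc2cc(F)ccc21`, gives 6460 nM, a gap that lies well beyond the usual scatter; the two structures differ in several places, so no single step connects them.

Compound 3 `CN(C)CCn1c(=O)c(=Cc2ccc(F)c(F)c2)s/c1=C1\C(=O)Nc2ccc(F)cc21` differs from compound 2 in one place: dimethylamino in place of (diethylamino)methyl on a saturated chain carbon, two bonds along the chain from an aromatic nitrogen. Within the data shown here, no measured step of this kind is available, and compound 1, which carries the shorter chain among other changes, gives 6460 nM. Compound 3 is therefore expected to lose some potency, at 1500 nM with a range of 500 nM to 4500 nM. The expected step of a 2.3-fold higher number from compound 2 to compound 3 (0.37 log units; beyond the scatter) is a moderate weakening, likely only partly beyond the scatter.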

Compound 3, half-maximal inhibitory concentration: 3090 nM
Estimate against measurement, compound 3: 2.1-fold (0.31 log units) below; measured number inside the range.
By their numbers in this assay, from the lowest: compound 2; then compound 3; then compound 1.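

In this assay, going by these compounds alone, this is the first reading of a single change at this position: dimethylamino in place of (diethylamino)methyl on a saturated chain carbon, two bonds along the chain from an aromatic nitrogen, gives a 4.8-fold higher number from compound 2 to compound 3 (0.68 log units; beyond the scatter) as a modest weakening. The side chain alone therefore moves the number while the rest of the structure stays the same. Nothing measured here explains the step. The compounds shown leave open whether the chain length or the groups on the nitrogen carry this step, as the two change together. A longer chain ending in dimethylamino, or a morpholine at the chain end, would be needed to tell more.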